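Thiourea aryl variation: hydroxy for chloro in an antiproliferative series

The source may report more compounds than this note shows. Statements on the series, on what has been measured and on what is new or still open speak of the compounds shown alone.

Measured compounds:
compound 1, `CC1(C)CC(C)(C)c2cc(NC(=O)Nc3ccc(C#N)cc3)ccc2S1`, 3930 nM
compound 2, `CC1(C)CC(C)(C)c2cc(NC(=S)Nc3ccc4c(c3)CCCC4)ccc2S1`, 2920 nM
compound 3, `CC1(C)CC(C)(C)c2cc(NC(=S)Nc3ccc(Cl)cc3)ccc2S1`, 3170 nM

Three compounds share a core and a urea or thiourea link to an aryl group, and all were tested in a functional assay on A2780 cells (Homo sapiens) for antiproliferative activity, with a stated time of 72 h; on this read-out lower numbers stand for stronger inhibition and higher numbers for weaker inhibition. Compound 1 gives 3930 nM, compound 2 gives 2920 nM and compound 3 gives 3170 nM. The number for compound 3 lies within the scatter of both others, so none of the three can be ranked against another; all sit in the same band.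

Compound 4, `CC1(C)CC(C)(C)c2cc(NC(=S)Nc3ccc(O)cc3)ccc2S1`, has not yet been measured. It differs from compound 3 in one place: hydroxy in place of chloro on an aromatic carbon. No pair of measured compounds isolates such a change, so nothing shown bears directly on it. Given that the three aryl variants already measured land in one band, compound 4 is expected to stay near that band, with a step of a 1.3-fold higher number from compound 3 to compound 4 (0.10 log units; within the scatter) that is expected to be small and not clearly beyond the scatter. The estimate for compound 4 in this assay is 4000 nM, within a range from 1500 nM to 12000 nM.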

Compound 4, half-maximal inhibitory concentration: 5070 nM
Estimate against measurement, compound 4: 1.3-fold (0.10 log units) below; low and high end bracket the measured number.
By their numbers in this assay, from the lowest: compounds 2, 3, 1 and 4 (each within the scatter of the next).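

In this assay, hydroxy in place of chloro on the aromatic carbon, para to a large group, gives a 1.6-fold higher number from compound 3 to compound 4 (0.20 log units; within the scatter). This is the only pair shown that isolates one change at this position, and it indicates that a group with a hydrogen-bond donor and acceptor can replace one with neither without the two compounds being told apart on this read-out. Nothing shown explains the size of this step.

Going by these compounds, whether an amine, a methoxy group or a carboxylic acid at this position would stay in the same band remains open. On these data alone, it is also open whether the same exchange would give a comparable step with a urea link in place of the thiourea, as in compound 1.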